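A few compounds are considered here, and "the series" means these few. Any claim that something is new, unique, unknown or untested is made for them only; others in the source may bear on it.

Measured compounds in an ADME assay on cells (Splenocyte, Mus musculus, strain BALB/c) for cytotoxicity, read by MTT assay, tested at 1 ug/mL; on this read-out higher numbers stand for a stronger effect at the one concentration tested and lower numbers for a weaker effect:
- compound 1, `CCCCCCCCCCCCCCC(N)COCc1ccccc1`, gives 0%
- compound 2, `CCCCCCCCCCCCCCC(COCc1ccccc1)NC(=O)CCCC(=O)O`, gives 0%
- compound 3, `CCCCCCCCCCCCCCC(CO)NC(=O)CCCC(=O)O`, gives "not determined" (no result reported)

Compound 3 stands without a number: no result was obtained for it, so nothing can be said of where it lies relative to compound 1 or compound 2. Within the data shown here, the one step measured so far, no change at the digits printed from compound 1 to compound 2 (within the scatter), adds the (3-carboxypropyl)carbonyl group to the amine nitrogen and leaves the read-out unchanged within the scatter; both compounds sit at the bottom of the scale.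

Compound 4, `CCCCCCCCCCCCCCC(CO)NCCCCCC`, differs from compound 3 as follows: hexyl in place of (3-carboxypropyl)carbonyl on an amine nitrogen. This change removes the group whose addition, from compound 1 to compound 2, produced no shift, and puts a hexyl chain in its place. Among the measured compounds shown here, no measured step covers a hexyl group on this nitrogen, so the step from compound 3 to compound 4 cannot be sized from the data. Given that the two compounds with a number both show no effect, compound 4 is expected at 3%, with a range from 0% to 15%.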

Compound 4, a percentage reported as activity, at one concentration (the size of the read-out at that concentration, not a potency): 5%
For compound 4 the middle estimate is 2 percentage points below the measured one; the range from low to high includes it.
By their numbers in this assay, from the lowest: compounds 1, 2 and 4 (each within the scatter of the next).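

Among these compounds, compound 3 has no number in this assay, so no step to compound 4 can be read. The compounds shown leave open how hexyl in place of (3-carboxypropyl)carbonyl on the amine nitrogen shifts this read-out. No evidence at hand bears on the result of compound 4.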